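Replacing the group on the carbonyl carbon: compound 4

A few compounds are considered here, and "the series" means these few. Any claim that something is new, unique, unknown or untested is made for them only; others in the source may bear on it.

Measured compounds:
compound 1, `Cc1nc(S(C)(=O)=O)ccc1Oc1ncnc(OC2CCN(C(=O)OC(C)C)CC2)c1F`: 77%
compound 2, `Cc1nc(S(C)(=O)=O)ccc1Oc1ncnc(OC2CCN(C(=O)OC3(C(F)(F)F)CCC3)CC2)c1F`: 82%
compound 3, `Cc1nc(S(C)(=O)=O)ccc1Oc1ncnc(OC2CCN(C(=O)SC3CC3)CC2)c1F`: 80%

All three share one core and differ only in the group attached to the carbonyl carbon. In a functional assay on isolated protein for inhibition of Glucose-dependent insulinotropic receptor (Rattus norvegicus), read by HTRF and cAMP accumulation (a lower number here means a smaller maximal response, a higher number a larger maximal response), compound 1 gives 77%, compound 2 gives 82% and compound 3 gives 80%. Compound 3 stands second highest of the three numbers; its nearest neighbour is compound 2, with a number 2 percentage points lower from compound 2 to compound 3 (within the scatter), and its furthest is compound 1, with a number 3 percentage points higher from compound 1 to compound 3 (within the scatter). All three values sit within the scatter of one another, so no order can be read among them.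

Compound 4, `Cc1nc(S(C)(=O)=O)ccc1Oc1ncnc(OC2CCN(C(=O)c3noc(C(C)(C)F)n3)CC2)c1F`, is the next member. The change from compound 3 is a group of 9 heavy atoms (5 carbon, 2 nitrogen, 1 oxygen, 1 fluorine; one five-membered aromatic ring with 3 hetero atoms) in place of a group of 4 heavy atoms (3 carbon, 1 sulfur; one three-membered non-aromatic ring of carbon only), on a carbonyl carbon.

Among the measured compounds shown here, three measured steps bear on this change, each altering the same group on the carbonyl carbon: a number 5 percentage points higher from compound 1 to compound 2 (within the scatter), a number 3 percentage points higher from compound 1 to compound 3 (within the scatter) and a number 2 percentage points lower from compound 2 to compound 3 (within the scatter). None of them moves the maximal response beyond the scatter, even where the entering group is larger and ring-containing. No step beyond the scatter is therefore expected in this assay for compound 4.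

For compound 4 the expected value in this assay is 80%, with a range from 68% to 92%. The implied step no change at the digits printed from compound 3 to compound 4 (within the scatter) is expected to stay within the scatter.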

Compound 4, largest response reached (reported as efficacy), in percent of the reference or control that the assay uses: 74%
The estimate for compound 4 lay 6 percentage points above the measured number; the range from low to high includes it.
By their numbers in this assay, from the lowest: compounds 4, 1, 3 and 2 (each within the scatter of the next).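

Among the compounds shown here, the five-membered aromatic ring with 3 hetero atoms brings an aromatic ring to the carbonyl carbon for the first time in this set, and in this assay the maximal response stays within the scatter of all the earlier compounds: a number 6 percentage points lower from compound 3 to compound 4 (within the scatter), a number 8 percentage points lower from compound 2 to compound 4 (within the scatter) and a number 3 percentage points lower from compound 1 to compound 4 (within the scatter). The range of entering groups compatible with this result therefore widens beyond the isopropyl, 1-(trifluoromethyl)cyclobutyl and cyclopropyl-bearing sulfur groups to one with more hydrogen-bond acceptors, and across all four compounds no group on the carbonyl carbon separates from the others in this assay. No supporting measurement bears on this result, so the steps cannot be linked to any feature of the entering group.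

Still open, going by these compounds, is whether a group of a different kind on the carbonyl carbon, such as a primary amine, a carboxylic acid or a longer alkyl chain, would carry the maximal response beyond the scatter. The compounds shown also do not separate the contribution of the five-membered aromatic ring from that of its fluorine, which a matching ring carrying hydrogen in place of fluorine would address.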